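This account rests on a few compounds, and the source may have more. Where it says the series, first, only, none or still open, it means among the compounds named here.

Three compounds have been measured in a functional assay on KB cells (Homo sapiens) for cytotoxicity, read by MTT assay, with a stated time of 48 h; a lower number here means a stronger inhibitor, a higher number a weaker inhibitor:

compound 1 `CCn1cc(-c2nc3ccccc3[nH]2)c(=O)c2cc(F)c(N3CCN(C)CC3)cc21`: 36700 nM
compound 2 `CCn1cc(-c2nc3ccccc3o2)c(=O)c2cc(F)c(Cl)cc21`: 10200 nM
compound 3 `CCn1cc(-c2nc3ccccc3o2)c(=O)c2cc(F)c(N3CCN(C)CC3)cc21`: 87400 nM

Compound 3 stands highest of the three numbers, that is, it is the weakest inhibitor in this assay. Its nearest neighbour is compound 1, with a 2.4-fold higher number from compound 1 to compound 3 (0.38 log units; beyond the scatter), and its furthest is compound 2, with an 8.6-fold higher number from compound 2 to compound 3 (0.93 log units; beyond the scatter).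

Compound 4 `CCn1cc(-c2nc3ccccc3s2)c(=O)c2cc(F)c(N3CCN(C)CC3)cc21` differs from compound 3 in one place: 1,3-benzothiazol-2-yl in place of 1,3-benzoxazol-2-yl on an aromatic carbon. Among the measured compounds shown here, of the measured steps, only the one from compound 1 to compound 3 bears on this change, since it too swaps the group on that aromatic carbon of the shared core, and it was modest, with a 2.4-fold higher number from compound 1 to compound 3 (0.38 log units; beyond the scatter). The step from compound 2 to compound 3 concerns a different position and gives no guidance. For the measured compounds named here, no measured pair shows the 1,3-benzothiazol-2-yl group, so the direction is uncertain; a step of modest size in either sense, or none beyond the scatter, is expected in this assay. Compound 4 is therefore estimated at 60000 nM, within 20000 nM to 180000 nM, which is expected to mean a 1.5-fold lower number from compound 3 to compound 4 (0.16 log units; within the scatter).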

Compound 4, half-maximal inhibitory concentration: 19000 nM
Compound 4: the middle estimate sits 3.2-fold (0.50 log units) above what was measured, outside the stated range (below it).
By their numbers in this assay, from the lowest: compounds 2, 4 and 1 (each within the scatter of the next, the first and the last beyond it); then compound 3.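

With the 4-methylpiperazin-1-yl group held constant, the change from 1,3-benzoxazol-2-yl to 1,3-benzothiazol-2-yl on this aromatic carbon gives a 4.6-fold lower number from compound 3 to compound 4 (0.66 log units; beyond the scatter) in this assay, so replacing the ring oxygen with sulfur has a measurable effect here. The 1,3-benzothiazol-2-yl group and the 1H-benzimidazol-2-yl group, by contrast, are not separated, with a 1.9-fold lower number from compound 1 to compound 4 (0.29 log units; within the scatter), which leaves compound 3 as the one that stands apart among these three groups at this position. Nothing available explains this difference.

The compounds shown leave open whether the 1,3-benzothiazol-2-yl group would behave the same way with chloro in place of 4-methylpiperazin-1-yl. They also leave open how a carboxylic acid on this same aromatic carbon would compare with these fused groups.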